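A few compounds are considered here, and "the series" means these few. Any claim that something is new, unique, unknown or untested is made for them only; others in the source may bear on it.

Working notes on the series built on the shared core, varied at one aromatic carbon of a six-membered aromatic ring with two nitrogen atoms, next to the ring nitrogen. Compound 1 `Brc1cn2ccnc2c(-c2ccc3ncn(C4CCCCC4)c3c2)n1` carries bromo at that carbon; in a functional assay on LOX IMVI cells (Homo sapiens) for inhibition, read by sulforhodamine B assay, with a stated time of 48 h, tested at 10 uM (a higher number here means more inhibition at the concentration tested (going by the name of the read-out), a lower number less inhibition), compound 1 gives 15.2%. Compound 2 `COc1ccc(-c2cn3ccnc3c(-c3ccc4ncn(C5CCCCC5)c4c3)n2)cc1` carries 4-methoxyphenyl and gives 69.6%. Compound 3 `c1cn2cc(-c3ccsc3)nc(-c3ccc4ncn(C5CCCCC5)c4c3)c2n1` carries thiophen-3-yl and gives 4.9%, the lowest of the three numbers: the step of a number 10.3 percentage points lower from compound 1 to compound 3 (beyond the scatter) is modest, the step of a number 64.7 percentage points lower from compound 2 to compound 3 (beyond the scatter) is large.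

Compound 4 `COc1ccccc1-c1cn2ccnc2c(-c2ccc3ncn(C4CCCCC4)c3c2)n1` follows from compound 3 by 2-methoxyphenyl in place of thiophen-3-yl on an aromatic carbon. Among the compounds with values here, two steps bear on it. Read in reverse, a number 64.7 percentage points lower from compound 2 to compound 3 (beyond the scatter) shows that a methoxyphenyl in place of thiophen-3-yl gave a large rise, and a number 54.4 percentage points higher from compound 1 to compound 2 (beyond the scatter) shows the same methoxyphenyl far ahead of bromo. Within the data shown here, the entering 2-methoxyphenyl is a relative of that group, not the same one, so no measured step matches it exactly. A large rise is therefore expected, a number 45.1 percentage points higher from compound 3 to compound 4 (beyond the scatter), with wide room for the difference between the two methoxyphenyl groups. Compound 4 is estimated at 50%, within 20% to 75%.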

Compound 4, a percentage reported as inhibition, at one concentration (the size of the read-out at that concentration, not a potency): 5.13%
Estimate against measurement, compound 4: 44.9 percentage points above, and the stated range ends above it.
By their numbers in this assay, from the lowest: compounds 3 and 4 (each within the scatter of the next); then compound 1; then compound 2.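

Compound 4 shows that at this carbon a methoxyphenyl group as such does not secure the high reading in this assay: the change from 4-methoxyphenyl to 2-methoxyphenyl costs nearly the whole signal (a number 64.5 percentage points lower from compound 2 to compound 4 (beyond the scatter)). The 2-methoxyphenyl group gives no separation from thiophen-3-yl (a number 0.2 percentage points higher from compound 3 to compound 4 (within the scatter)) and falls short of bromo (a number 10.1 percentage points lower from compound 1 to compound 4 (beyond the scatter)), so among the four groups shown only 4-methoxyphenyl exceeds bromo, with compound 3 and compound 4 going against any general gain from a ring at this carbon. Nothing available gives a reason for the gap between the two methoxyphenyl groups.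

Open, on these data alone, is whether the high reading of compound 2 depends on the methoxy group itself or on the phenyl ring. A plain phenyl, or a phenyl carrying an amine in place of that methoxy, would bear on this.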